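Aryl swap on the sulfonamide nitrogen

The compounds below may be only part of what the source reports. "The series", "measured", "known", "first", "only" and "open" are said of these compounds alone.

Measured in a functional assay on DU-145 cells (Homo sapiens) for antiproliferative activity, read by MTT assay, with a stated time of 72 h; on this read-out lower numbers stand for stronger inhibition and higher numbers for weaker inhibition:
compound 1 `Cc1cccc(N(C)S(=O)(=O)C2CC3OC2C(c2ccc(NC(=O)CCCCCCC(=O)O)cc2)=C3c2ccc(O)cc2)c1`: > 100000 nM (a limit of the assay, not a number)
compound 2 `CN(c1ccc(Cl)cc1)S(=O)(=O)C1CC2OC1C(c1ccc(NC(=O)CCCCCCC(=O)O)cc1)=C2c1ccc(O)cc1`: 72100 nM
compound 3 `CCN(c1cccc(C)c1)S(=O)(=O)C1CC2OC1C(c1ccc(NC(=O)CCCCCCC(=O)O)cc1)=C2c1ccc(O)cc1`: 65600 nM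

Compound 3 cannot be separated from its nearest neighbour: a 1.1-fold lower number from compound 2 to compound 3 (0.04 log units; within the scatter). The next compound, compound 4 `CCN(c1ccccc1Cl)S(=O)(=O)C1CC2OC1C(c1ccc(NC(=O)CCCCCCC(=O)O)cc1)=C2c1ccc(O)cc1`, carries 2-chlorophenyl in place of 3-methylphenyl on a sulfonamide nitrogen. The closest measured precedent is the other exchange of aryl groups at this nitrogen: an at least 1.3-fold lower number from compound 1 to compound 2 (0.14 log units; that floor lies within the scatter). Only a floor is known for that step because of the limit of > 100000 nM in this assay, at which 1 of the 3 values shown sits. The same holds for the exchange on the chain carbon: an at least 1.5-fold lower number from compound 1 to compound 3 (0.18 log units; that floor lies within the scatter). Among the measured compounds shown here, no compound bearing 2-chlorophenyl has a value yet. All three steps, floors included, lie within the scatter, so no step beyond the scatter is expected in this assay. The expected step is a 1.1-fold lower number from compound 3 to compound 4 (0.02 log units; within the scatter). For compound 4 the estimated value is 62000 nM, with an expected range from 30000 nM to 100000 nM.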

Compound 4, half-maximal inhibitory concentration: > 100000 nM
Compound 4: no number, only a limit; the forecaster's own chance of this, stated with the estimate: 20%; at least 1.6-fold (0.20 log units) between middle value and limit.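

In this assay compound 4 gives > 100000 nM, which is a limit of the assay and not a number, so this first 2-chlorophenyl on the sulfonamide nitrogen yields no readable value. Exchanging 3-methylphenyl for 2-chlorophenyl gives an at least 1.5-fold higher number from compound 3 to compound 4 (0.18 log units; that floor lies within the scatter), and the wider change in the sulfonyl substituent gives an at least 1.3-fold higher number from compound 2 to compound 4 (0.14 log units; that floor lies within the scatter), while the step from compound 1 cannot be read. Both readable steps are floors that lie within the scatter, so no real loss from either change is established, and their true size stays unknown because of the assay ceiling: the limit of > 100000 nM in this assay, at which 2 of the 4 values shown sit.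

Going by these compounds, whether any aryl group on this nitrogen brings the value well clear of that limit remains open, as does whether 2-chlorophenyl behaves the same with methyl in place of ethyl. Also open, on these data alone, is whether a hydroxamic acid in place of the carboxylic acid would change the read-out of this series.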